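Ring swap at the amine carbon: compound 4 outlook

The compounds below may be only part of what the source reports. "The series", "measured", "known", "first", "only" and "open" are said of these compounds alone.

The shared core is carried by compound 1 `Cc1ccc2c(NCc3ccc(NC(=O)C4CCN(Cc5ccc(F)cc5)CC4)cc3)nc(N(C)C)nc2c1`, compound 2 `Cc1ccc2c(NCc3ccc(NC(=O)C4CCN(Cc5cccc(F)c5)CC4)cc3)nc(N(C)C)nc2c1`, compound 3 `Cc1ccc2c(NCc3ccc(NC(=O)C4CCN(Cc5ncc[nH]5)CC4)cc3)nc(N(C)C)nc2c1` and the unmeasured compound 4 `Cc1ccc2c(NCc3ccc(NC(=O)C4CCN(Cc5ccccc5F)CC4)cc3)nc(N(C)C)nc2c1`. In a functional assay on SV5A8 cells (Homo sapiens) for cytotoxicity (on this read-out lower numbers stand for stronger inhibition and higher numbers for weaker inhibition), compound 1 reports only a limit, > 4820 nM. In this assay compound 2 likewise reports only a limit, > 4170 nM. In this assay compound 3 also stands at a limit, > 20000 nM. All three values shown are limits, so compound 3 cannot be placed above or below the others. The steps a step that the two limits leave unreadable from compound 1 to compound 2, a step that the two limits leave unreadable from compound 1 to compound 3 and a step that the two limits leave unreadable from compound 2 to compound 3 are accordingly not readable in size or direction.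

Compound 4 differs from compound 3 by 2-fluorophenyl in place of 1H-imidazol-2-yl on a saturated chain carbon bound to an amine nitrogen in a ring. Among the compounds with values here, the steps that bear on this change are a step that the two limits leave unreadable from compound 1 to compound 3 and a step that the two limits leave unreadable from compound 2 to compound 3, both ending at the 1H-imidazol-2-yl compound and both unreadable, with the values sitting at the limit of > 20000 nM in this assay, at which 1 of the 3 values shown sits, the limit of > 4170 nM in this assay, at which 1 of the 3 values shown sits, and (the limit of > 4820 nM in this assay, at which 1 of the 3 values shown sits). With a 2-fluorophenyl entering, compound 4 is expected to behave like the other fluorophenyl members and to return a limit rather than a number. The estimated step of an at least 2.0-fold lower number from compound 3 to compound 4 (0.30 log units; that floor lies within the scatter) is therefore expected to carry little weight. Compound 4 is estimated at 10000 nM, within a range from 3000 nM to 40000 nM.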

Compound 4, half-maximal inhibitory concentration: > 6670 nM
Compound 4: only a limit was reported (the forecaster's own chance of this, stated with the estimate: 80%); the middle value lies beyond the limit too.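

In this assay compound 4 gives > 6670 nM, which is a limit. Within the data shown here, compound 1, compound 2 and compound 3 also stand at limits, so no step from any of them to compound 4 can be read in size or direction. The compounds shown leave open whether 2-fluorophenyl, 3-fluorophenyl, 4-fluorophenyl and 1H-imidazol-2-yl differ at all on this read-out.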